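This account rests on a few compounds, and the source may have more. Where it says the series, first, only, none or still open, it means among the compounds named here.

Measured so far in a functional assay on MDA-MB-436 cells (Homo sapiens) for antiproliferative activity, read by MTT assay, with a stated time of 24 h (a higher number here means a weaker inhibitor, a lower number a stronger inhibitor), as read-outs of half-maximal inhibitory concentration:
- compound 1 (`O=C(O)CC(NC(=O)c1ccc(F)cc1)c1ccccc1F`) at > 100000 nM as a limit
- compound 2 (`O=C(O)CC(NC(=O)c1cccc(Br)c1)c1ccccc1F`) at > 100000 nM as a limit

In this assay compound 1 stands at > 100000 nM as a limit and not as a number. The next compound is compound 3 (`O=C(O)CC(NC(=O)c1ccc(C(F)(F)F)cc1)c1ccccc1F`). Its change from compound 1 is trifluoromethyl in place of fluoro on an aromatic carbon and amounts to trifluoromethyl in place of fluoro on an aromatic carbon.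

Within the data shown here, the one measured step is a step that the two limits leave unreadable from compound 1 to compound 2 and it also changes the group on the carbonyl carbon, yet with both ends at limits it gives no size. The evidence amounts to the limit of > 100000 nM in this assay, at which 2 of the 2 values shown sit, and no more. No direction can be drawn from it. With compound 2 at > 100000 nM as a limit, compound 3 is expected to stay unresolved in this assay and most likely to be reported as a limit too. The expected size of a step that the limit leaves unreadable from compound 1 to compound 3 is nothing beyond the scatter. For compound 3 the estimated value is 130000 nM with an expected range from 50000 nM to 400000 nM if a number is reported at all.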

Compound 3, half-maximal inhibitory concentration: 66800 nM
Beside the measured number, compound 3's estimate is 1.9-fold (0.29 log units) above it; the measured number falls inside the stated range.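

In this assay, compound 3 is the first compound shown in this series to give a number and not a limit, at 66800 nM. Trifluoromethyl in place of fluoro on an aromatic carbon, para to a large group, comes with an at least 1.4-fold lower number from compound 1 to compound 3 (0.17 log units; that floor lies within the scatter); this step starts from a limit, so its true size remains unknown and a shift beyond the scatter is not established. The number therefore shows only that this position can carry trifluoromethyl with a readable value in the assay, while the rest of the series gives no numbers to set beside it: the limit of > 100000 nM in this assay, at which 2 of the 3 values shown sit.

As far as these compounds go, it remains open whether a number at this position is specific to trifluoromethyl, or whether a nitrile, a methoxy group or a longer chain in the same place would also give a readable value in this assay, and how far any of these would lie from compound 3. From the compounds shown here alone, it is equally open whether a readable value would survive if the carboxylic acid of the shared core gave way to a methyl ester or a primary amide.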